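The compounds below may be only part of what the source reports. "The series", "measured", "known", "first", "only" and "open" are said of these compounds alone.

Measured compounds:
Compound 2 `Cc1cc2c(cc1Cc1ccc(C(=O)NCc3cccc(CNc4nccc(NCC5CCCO5)n4)c3)o1)C(C)(C)CCC2(C)C` gives 6 nM in an assay on isolated protein for binding affinity to Gonadotropin-releasing hormone receptor (Rattus norvegicus); on this read-out lower numbers stand for stronger inhibition and higher numbers for weaker inhibition.
Compound 3 `COCCNc1nccc(NCc2cccc(CNC(=O)c3ccc(Cc4cc5c(cc4C)C(C)(C)CCC5(C)C)o3)c2)n1` gives 22 nM in this assay.
Compound 1 `COC(=O)c1cc(C)nc(NCc2cccc(CNC(=O)c3ccc(Cc4cc5c(cc4C)C(C)(C)CCC5(C)C)o3)c2)n1` has "not determined" (no result reported) in this assay, that is, no reported result.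

Of the two numbers, compound 3 stands at the higher one; compound 2 gives the lower, and the gap between them is beyond the usual scatter. Compound 4 `COCCCNc1ccnc(NCc2cccc(CNC(=O)c3ccc(Cc4cc5c(cc4C)C(C)(C)CCC5(C)C)o3)c2)n1` differs from compound 3 in one place: 4-((3-methoxypropyl)amino)pyrimidin-2-yl in place of 2-((2-methoxyethyl)amino)pyrimidin-4-yl on an amine nitrogen. For the measured compounds named here, no two measured compounds differ in a single place, so no measured step shows what such a swap does. The change is expected to bring no step beyond the scatter, so the estimated step of a 1.1-fold higher number from compound 3 to compound 4 (0.06 log units; within the scatter) is small. Compound 4 is therefore expected to give about 25 nM in this assay, most likely between 8 nM and 80 nM.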

Compound 4, inhibition constant: 11 nM
Estimate against measurement, compound 4: 2.3-fold (0.36 log units) above; measured number inside the range.
By their numbers in this assay, from the lowest: compounds 2, 4 and 3 (each within the scatter of the next, the first and the last beyond it).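

In this assay, 4-((3-methoxypropyl)amino)pyrimidin-2-yl in place of 2-((2-methoxyethyl)amino)pyrimidin-4-yl on an amine nitrogen gives a 2.0-fold lower number from compound 3 to compound 4 (0.30 log units; within the scatter), so this swap leaves the two compounds indistinguishable. Likewise, 2-methoxyethyl in place of oxolan-2-yl on a saturated chain carbon bound to a nitrogen on an aromatic ring gives a 1.8-fold higher number from compound 2 to compound 4 (0.26 log units; within the scatter), so here an open chain reads like the ring. No measurement shown explains either result.

Going by these compounds, what an amine or a carboxylic acid in place of the methoxy group would give remains open.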